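The source may report more compounds than this note shows. Statements on the series, on what has been measured and on what is new or still open speak of the compounds shown alone.

Measured so far in a physicochemical assay for lipophilicity, read by HPLC, measured as octanol-water partition; on this read-out lower numbers stand for lower lipophilicity and higher numbers for higher lipophilicity:

Compound 1, `COc1ccc(N(CC(=O)NCCCSc2ccccc2)C(=O)CCSC2=C(C)C(=O)c3ccccc3C2=O)cc1`, gives 4.2.
Compound 2, `COc1ccc(N(CC(=O)NCCC[Se]c2ccccc2)C(=O)CCSC2=C(C)C(=O)c3ccccc3C2=O)cc1`, gives 4.23.
Compound 3, `COc1ccc(N(CC(=O)NCCC[Se]c2ccccc2)C(=O)C#Cc2ccccc2)cc1`, gives 2.6.

Compound 1 and compound 2 share one core and differ in a single place: a group of 7 heavy atoms (6 carbon, 1 sulfur; one six-membered aromatic ring of carbon only) in place of a group of 7 heavy atoms (6 carbon, 1 selenium; one six-membered aromatic ring of carbon only), on a saturated chain carbon, three bonds along the chain from an amide-type nitrogen. This exchange produced a step of a number 0.03 log units lower from compound 2 to compound 1 (within the scatter), so the two values cannot be told apart in this assay.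

Compound 3 carries a different core. How its core differs from that of compound 2 is not broken down here. In this assay compound 3 stands lowest of the three measured compounds, and its gap to compound 1 and to compound 2 lies beyond the scatter.

Compound 4, `COc1ccc(N(CC(=O)NCCCSc2ccccc2)C(=O)C#Cc2ccccc2)cc1`, has not yet been measured. It is related to compound 3 in the same way that compound 1 is related to compound 2: the change is a group of 7 heavy atoms (6 carbon, 1 sulfur; one six-membered aromatic ring of carbon only) in place of a group of 7 heavy atoms (6 carbon, 1 selenium; one six-membered aromatic ring of carbon only), on a saturated chain carbon, three bonds along the chain from an amide-type nitrogen. Going by the values given here, this is the same change, at the same place, as the one already seen between compound 2 and compound 1. Because that earlier change gave a number 0.03 log units lower from compound 2 to compound 1 (within the scatter), the step from compound 3 to compound 4 in this assay is expected to be of like size, estimated at a number 0.03 log units lower from compound 3 to compound 4 (within the scatter). On that basis compound 4 is expected to give about 2.57 in this assay, most likely between 2.3 and 2.9.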

Compound 4, partition coefficient: 3.4
Beside the measured number, compound 4's estimate is 0.83 log units below it; the whole stated range lies below it.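

Carrying the change from one core to the other in this assay did not give a like step: putting phenylsulfanyl in place of the group with selenium gave one step on the first core (a number 0.03 log units lower from compound 2 to compound 1 (within the scatter)) and another on the second (a number 0.80 log units higher from compound 3 to compound 4 (beyond the scatter)). This shows that, in these two pairs, the step read on one core was no safe guide to the step on the other, even though the change and its place, on a saturated chain carbon, three bonds along the chain from an amide-type nitrogen, were the same. It does not show a rule for other cores, since two pairs cannot set one, and nothing available here explains why the two steps differ.

The compounds shown leave open how the same exchange would read in this assay on any third core, so it remains unknown which of the two steps would be the more typical one. They also leave open what a phenoxy group or a longer chain, in the same place on either core, would give.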